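This account rests on a few compounds, and the source may have more. Where it says the series, first, only, none or still open, it means among the compounds named here.

Compounds measured so far in an ADME assay on PANC-1 cells (Homo sapiens) for cytotoxicity, read by MTT assay, with a stated time of 48 h; on this read-out higher numbers stand for weaker inhibition of growth and lower numbers for stronger inhibition of growth:
- compound 1 `O=C(/C=C\c1cccc(Cl)c1)N1N=C(c2ccncc2)OC1c1c[nH]c2ccccc12`: > 30 ug/mL, a limit of the assay
- compound 2 `O=C(/C=C\c1cccc(Cl)c1Cl)N1N=C(c2ccncc2)OC1c1c[nH]c2ccccc12`: > 30 ug/mL, a limit of the assay

Compound 2 stands only at a limit in this assay, with no numerical value behind it. Compound 1 likewise gives only a limit in this assay. The step that the two limits leave unreadable from compound 1 to compound 2 is therefore not readable; both values sit at the limit of > 30 ug/mL in this assay, at which 2 of the 2 values shown sit.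

Compound 3 `O=C(/C=C\c1ccc(Br)cc1)N1N=C(c2ccncc2)OC1c1c[nH]c2ccccc12` differs from compound 2 by 4-bromophenyl in place of 2,3-dichlorophenyl on a double-bonded chain carbon bound to a double-bonded chain carbon. Within the data shown here, no measured step reflects this change, and the only step on hand is unreadable, so nothing points to a direction. Given that compound 2 gives > 30 ug/mL in this assay, compound 3 is expected to remain near the same limit, with the step that the limit leaves unreadable from compound 2 to compound 3 estimated as none beyond the scatter. For compound 3 the estimate in this assay is 35 ug/mL, ranging from 15 ug/mL to 80 ug/mL.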

Compound 3, concentration for 50% growth inhibition: > 30 ug/mL
Compound 3 ended at the assay's limit; the forecaster's own chance of this, stated with the estimate: 75%; the middle value is on the limit's open side.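

No step can be read among compound 1, compound 2 and compound 3 in this assay, as each value is a limit of the assay: the limit of > 30 ug/mL in this assay, at which 3 of the 3 values shown sit.

The compounds shown leave open whether these three differ at all in growth inhibition, and which change to the series would give a value inside the limit.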